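Chloro on the benzyl ring: a urea analogue awaits testing

The source may hold more compounds than are shown below. What is called first, only, known or untested is meant among the compounds shown, and "the series" means these compounds.

Compound 1 `Cc1ccc(NC(=S)NC(=O)c2ccc(OCc3cccc(Cl)c3Cl)cc2)cc1-c1nc2ccccc2[nH]1`: > 100000 nM
Compound 2 `Cc1ccc(NC(=S)NC(=O)c2ccc(OCc3ccccc3Cl)cc2)cc1-c1nc2ccccc2[nH]1`: 51400 nM
Compound 3 `Cc1ccc(NC(=O)NC(=O)c2ccc(OCc3ccccc3)cc2)cc1-c1nc2ccccc2[nH]1`: 35100 nM

All three were tested in a functional assay on MNK45 cells (Homo sapiens) for inhibition, read by MTT assay, with a stated time of 48 h; a lower number here means a stronger inhibitor, a higher number a weaker inhibitor. Compound 1 reached only the limit of this assay, > 100000 nM, so no number is known for it (the limit of > 100000 nM in this assay, at which 1 of the 3 values shown sits). Compound 2 gave 51400 nM, and compound 3 gave 35100 nM. The values of compound 2 and compound 3 sit within the usual scatter of each other, so neither can be said to be stronger.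

Compound 1 differs from compound 2 by one change, (chloro in place of hydrogen on an aromatic carbon), and that change gave an at least 1.9-fold higher number from compound 2 to compound 1 (0.28 log units; that floor lies within the scatter). The difference between the core of compound 2 and the core of compound 3 is not broken down here.

Compound 4 `Cc1ccc(NC(=O)NC(=O)c2ccc(OCc3cccc(Cl)c3)cc2)cc1-c1nc2ccccc2[nH]1` has not yet been measured in this assay. It differs from compound 3 by chloro in place of hydrogen on an aromatic carbon. This is the same kind of change as from compound 2 to compound 1, but not the same: there the entering chloro sat ortho to a chloro group as well as meta to a large group, whereas in compound 4 it sits only meta to a large group.

The earlier step rests on a limit and lies within the scatter, so it gives little guidance. Compound 4 is therefore expected to land close to compound 3, with a step of about a 1.4-fold higher number from compound 3 to compound 4 (0.15 log units; within the scatter), and an estimated value of 50000 nM, most likely between 20000 nM and 120000 nM.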

Compound 4, half-maximal inhibitory concentration: 28000 nM
Compound 4: the middle estimate sits 1.8-fold (0.25 log units) above what was measured, within the range that was stated.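

In this assay, turning benzyl into 3-chlorobenzyl gives a 1.3-fold lower number from compound 3 to compound 4 (0.10 log units; within the scatter), a step too small to tell the two compounds apart. Setting this beside the earlier chloro step on the other core does not settle whether the change behaves alike on both: the same change on two cores in this assay, an at least 1.9-fold higher number (0.28 log units; that floor lies within the scatter) from compound 2 to compound 1 and a 1.3-fold lower number (0.10 log units; within the scatter) from compound 3 to compound 4; the limit leaves it open whether they differ. The compounds shown therefore do not establish that adding a chloro moves the result on either core, nor that its effect carries over from one core to the other, and the chloro does not enter at the same place on the ring in the two steps.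

Open questions remain about how other groups at this place on the benzyl ring, such as a methoxy group, an amine or a carboxylic acid, would read out on the core of compound 4, and about how the two cores would compare if both carried exactly the same chlorobenzyl group. Also open is how far the earlier step really reaches, since one of its two ends is a limit of the assay and not a number: the limit of > 100000 nM in this assay, at which 1 of the 4 values shown sits.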